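Tolerated concentration notes across compounds 1 to 3

The source may hold more compounds than are shown below. What is called first, only, known or untested is meant among the compounds shown, and "the series" means these compounds.

Compound 1 `Cc1cc(=O)oc2cc(OCC(O)CN3CCC(C(N)=O)CC3)ccc12` carries hydrogen on an aromatic carbon of the shared core; in an ADME assay on A549 cells (Homo sapiens) for cytotoxicity, read by CellTiter-Glo (a higher number here means that more compound is tolerated, a lower number that less compound is tolerated), compound 1 reaches only a limit of the assay, > 100000 nM. That limit is recorded as the limit of > 100000 nM in this assay, at which 1 of the 2 values shown sits. Within the data shown here, compound 2 `Cc1c(Cc2ccc(F)cc2Cl)c(=O)oc2cc(OCC(O)CN3CCC(C(N)=O)CC3)ccc12` gives 90800 nM in this assay, the only actual number in the set. The step of an at least 1.1-fold lower number from compound 1 to compound 2 (0.04 log units; that floor lies within the scatter) is the sole measured one and stays within the scatter. Compound 3 `Cc1c(Cc2ccccc2C(F)(F)F)c(=O)oc2cc(OCC(O)CN3CCC(C(N)=O)CC3)ccc12` differs from compound 2 by 2-(trifluoromethyl)phenyl in place of 2-chloro-4-fluorophenyl on a saturated chain carbon bound to an aromatic carbon. Among the measured compounds shown here, no measured step covers this exchange; the one step on record, from hydrogen to a substituted benzyl, moved the number by no more than the scatter, and the present change keeps a benzyl and trades only its ring substituents. The expected step of a 1.0-fold lower number from compound 2 to compound 3 (0.00 log units; within the scatter) is therefore of no size beyond the scatter. The estimate for compound 3 in this assay is 90000 nM, with a range of 40000 nM to 200000 nM.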

Compound 3, half-maximal cytotoxic concentration: > 100000 nM
Compound 3 ended at the assay's limit; the forecaster's own chance of this, stated with the estimate: 40%; middle value at least 1.1-fold (0.04 log units) from the limit.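

Swapping the ring substituents of the benzyl group on a saturated chain carbon bound to an aromatic carbon gives, in this assay, an at least 1.1-fold higher number from compound 2 to compound 3 (0.04 log units; that floor lies within the scatter), so a second substituted benzyl group at this place yields no step that can be shown to exceed the scatter. This step is only a floor, and the step between compound 1 and compound 3 cannot be read, as both of its ends are limits. Limits now make up most of the series: the limit of > 100000 nM in this assay, at which 2 of the 3 values shown sit.

Going by these compounds, it remains open whether any group at this place would give a step beyond the scatter, such as a benzyl group carrying an amine or a carboxylic acid, or a longer chain in place of the benzyl group. On these data alone, how far compound 1 and compound 3 lie past their limits also stays open.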